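The source may hold more compounds than are shown below. What is called first, only, known or untested is meant among the compounds shown, and "the series" means these compounds.

Three compounds share one core here: compound 1 (`O=C1/C(=C/c2ccccc2)CCC/C1=C\c1ccc([N+](=O)[O-])cc1`), compound 2 (`O=C1/C(=C/c2ccc(Cl)cc2)CCC/C1=C\c1ccc([N+](=O)[O-])cc1`) and compound 3 (`CN(C)c1ccc(/C=C2\CCC/C(=C\c3ccc([N+](=O)[O-])cc3)C2=O)cc1`). Going by the values given here, in a functional assay on HL-60 cells (Homo sapiens) for cytotoxicity, with a stated time of 24 h (on this read-out lower numbers stand for higher toxicity in this test and higher numbers for lower toxicity in this test), compound 1 gives 20000 nM and compound 2 gives 4100 nM, so compound 2 holds the lower of the two numbers so far. Compound 3 carries dimethylamino in place of chloro on an aromatic carbon, para to a large group (dimethylamino in place of chloro on an aromatic carbon). Among the compounds with values here, only one measured step bears on this change: a 4.9-fold lower number from compound 1 to compound 2 (0.69 log units; beyond the scatter). That modest step put chloro in place of hydrogen at the same place, so it shows that this assay can respond to a change there. It says nothing about dimethylamino, which has not been measured on this core. The data therefore give no direction for the new group, and no step beyond the scatter is expected, although a step as large as the measured one remains possible either way. The estimate starts from compound 2 at 4100 nM. The estimated step is a 1.2-fold higher number from compound 2 to compound 3 (0.09 log units; within the scatter). For compound 3 the expected value is 5000 nM, within an estimated range of 1200 nM to 20000 nM.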

Compound 3, half-maximal cytotoxic concentration: > 400000 nM
Compound 3 ended at the assay's limit; the forecaster's own chance of this, stated with the estimate: 5%; middle value at least 80-fold (1.90 log units) from the limit.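

In this assay compound 3 stands at > 400000 nM, which is a limit of the assay and not a number. This position therefore answers in both directions on the shared core: chloro in place of hydrogen gave a 4.9-fold lower number from compound 1 to compound 2 (0.69 log units; beyond the scatter), whereas dimethylamino in place of hydrogen gave an at least 20-fold higher number from compound 1 to compound 3 (1.30 log units; beyond the scatter), and exchanging chloro for dimethylamino gave an at least 97-fold higher number from compound 2 to compound 3 (1.98 log units; beyond the scatter). The exchange of one group for the other at this place thus produced a large step where the earlier compounds had shown only a modest one, and its full size stays unknown, as both new steps are bounded on one side only: the limit of > 400000 nM in this assay, at which 1 of the 3 values shown sits.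

The compounds shown leave open whether this loss of toxicity in the test goes with the nitrogen itself or with its two methyl groups, which an unsubstituted amine or a methoxy group at the same place could help to separate. They also leave open whether fluoro or bromo would follow chloro in moving the number down from that of compound 1.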